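This account rests on a few compounds, and the source may have more. Where it says the series, first, only, none or still open, it means among the compounds named here.

Compounds measured in a functional assay on PANC-1 cells (Homo sapiens) for inhibition, read by MTT assay, with a stated time of 72 h; a higher number here means a weaker inhibitor of growth, a lower number a stronger inhibitor of growth:

Compound 1, `O=S(=O)(NCCCNCc1cccc2ccccc12)c1cc(C(F)(F)F)cc(C(F)(F)F)c1` — 2700 nM
Compound 2, `COc1ccc(CNCCCNS(=O)(=O)c2cc(C(F)(F)F)cc(C(F)(F)F)c2)cc1OC` — 18000 nM
Compound 3, `COc1cccc(CNCCCNS(=O)(=O)c2cc(C(F)(F)F)cc(C(F)(F)F)c2)c1` — 10000 nM

Among these three, compound 3 gives the second highest number; its nearest neighbour is compound 2, with a 1.8-fold lower number from compound 2 to compound 3 (0.26 log units; within the scatter), while its furthest is compound 1, with a 3.7-fold higher number from compound 1 to compound 3 (0.57 log units; beyond the scatter). Compound 4, `O=S(=O)(NCCCNCC1COc2ccccc2O1)c1cc(C(F)(F)F)cc(C(F)(F)F)c1`, has not yet been measured in this assay. It differs from compound 3 by 2,3-dihydro-1,4-benzodioxin-2-yl in place of 3-methoxyphenyl on a saturated chain carbon bound to an amine nitrogen.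

Among the compounds with values here, two measured steps bear on this change in a loose way. Replacing naphthalen-1-yl by 3,4-dimethoxyphenyl gave a 6.7-fold higher number from compound 1 to compound 2 (0.82 log units; beyond the scatter), and replacing it by 3-methoxyphenyl gave a 3.7-fold higher number from compound 1 to compound 3 (0.57 log units; beyond the scatter). The step between the two methoxyphenyl compounds, a 1.8-fold lower number from compound 2 to compound 3 (0.26 log units; within the scatter), was within the scatter. Within the data shown here, no measured pair shows a 2,3-dihydro-1,4-benzodioxin-2-yl group, so the direction of its effect cannot be read from the data. The expectation is therefore a step of a 1.3-fold lower number from compound 3 to compound 4 (0.10 log units; within the scatter), with a wide range on either side.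

Compound 4 is estimated at 8000 nM, with a range from 3000 nM to 25000 nM.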

Compound 4, concentration for 50% growth inhibition: 3400 nM
Compound 4: middle estimate off by 2.4-fold (0.37 log units), on the high side; measured number inside the range.
By their numbers in this assay, from the lowest: compounds 1 and 4 (each within the scatter of the next); then compounds 3 and 2 (each within the scatter of the next).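

In this assay, the 2,3-dihydro-1,4-benzodioxin-2-yl group on a saturated chain carbon bound to an amine nitrogen separates from both methoxyphenyl compounds, with a 2.9-fold lower number from compound 3 to compound 4 (0.47 log units; beyond the scatter) and a 5.3-fold lower number from compound 2 to compound 4 (0.72 log units; beyond the scatter). Against naphthalen-1-yl there is no separation (step: a 1.3-fold higher number from compound 1 to compound 4 (0.10 log units; within the scatter)), so among these compounds the lowest numbers are no longer tied to naphthalen-1-yl alone, while compound 2 and compound 3 remain the exceptions with higher numbers. Nothing available here accounts for these steps.

The compounds shown leave open whether a plain phenyl or a naphthalen-2-yl group at this place would stand with compound 4 or with compound 3. They also leave open whether the step from compound 3 to compound 4 would persist with a longer chain in the shared core.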